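A few compounds are considered here, and "the series" means these few. Any claim that something is new, unique, unknown or untested is made for them only; others in the source may bear on it.

Working notes on the series.

Compound 2 `COc1cc(OC)c(-c2coc3cc(OCc4ccc([N+](=O)[O-])cc4)ccc3c2=O)cc1OC` shares its core with compound 1 `C=CCOc1ccc2c(=O)c(-c3cc(OC)c(OC)cc3OC)coc2c1`; the two differ only at the group on a saturated chain carbon bound to an oxygen on an aromatic ring. In a functional assay on HUVEC cells (Homo sapiens) for antiproliferative activity, read by MTT assay, with a stated time of 24 h (a lower number here means a stronger inhibitor, a higher number a weaker inhibitor), compound 1 gives only a limit, > 10000 nM. In this assay compound 2 likewise gives only a limit, > 10000 nM. The step that the two limits leave unreadable from compound 1 to compound 2 therefore cannot be read, and the limit of > 10000 nM in this assay, at which 2 of the 2 values shown sit, is all the evidence the two measured compounds provide: compound 2 stands at that limit, with no number to place it against.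

Compound 3 `COc1cc(OC)c(-c2coc3cc(OCc4cccc(Br)c4)ccc3c2=O)cc1OC` is not yet measured. It differs from compound 2 by 3-bromophenyl in place of 4-nitrophenyl on a saturated chain carbon bound to an oxygen on an aromatic ring. Cut one bond further out, the same difference reads (4-nitrobenzyl)oxy to (3-bromobenzyl)oxy. Going by the values given here, no measured step bears on this change, since the only step in the set is unreadable. The expectation for compound 3 in this assay therefore rests on compound 2 alone and its limit > 10000 nM, so compound 3 is expected to give about 10000 nM, with a range from 3000 nM to 30000 nM, an expected step of a number no higher from compound 2 to compound 3 (the limit leaves the size open), which most likely means another limit rather than a number.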

Compound 3, half-maximal inhibitory concentration: > 10000 nM
Compound 3: a limit, no number; the forecaster's own chance of this, stated with the estimate: 70%; the middle value sits exactly at the limit.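

In this assay compound 3 gives > 10000 nM, which is a limit and not a number. No step among compound 1, compound 2 and compound 3 can be read, and the evidence stops at the shared limit: the limit of > 10000 nM in this assay, at which 3 of the 3 values shown sit.

The compounds shown leave open whether any group at this place on the shared core gives a readable number in this assay.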